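Cyano in place of methyl and toxicity to cells

The compounds below may be only part of what the source reports. "The series", "measured", "known", "first", "only" and "open" are said of these compounds alone.

Three compounds have been measured in a functional assay on MT4 cells (Homo sapiens) for cytotoxicity (a higher number here means a weaker inhibitor, a lower number a stronger inhibitor), and each gives only a limit of the assay, not a number:

Compound 1, `Cc1ccccc1[S+]([O-])c1cccc(N)c1C#N`: > 200000 nM
Compound 2, `Cc1cccc([S+]([O-])c2cccc(N)c2C#N)c1`: > 200000 nM
Compound 3, `N#Cc1ccccc1[S+]([O-])c1cccc(N)c1C#N`: > 200000 nM

Compound 3 differs from compound 1 by cyano in place of methyl on an aromatic carbon. The step that the two limits leave unreadable from compound 1 to compound 3 cannot be read, since (the limit of > 200000 nM in this assay, at which 3 of the 3 values shown sit). Compound 2 is built from the same atoms as compound 1, joined differently; the difference between the two cores is not broken down here.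

Compound 4, `N#Cc1cccc([S+]([O-])c2cccc(N)c2C#N)c1`, has not yet been measured in this assay. It differs from compound 2 by cyano in place of methyl on an aromatic carbon. Among the compounds with values here, this is the same kind of change as the one from compound 1 to compound 3, but not the same: in compound 3 the cyano sits ortho to a large group, in compound 4 it sits meta to a large group.

A step of a number no higher from compound 2 to compound 4 (the limit leaves the size open) is expected, resting on compound 1 and compound 3, which both sit at the limit of > 200000 nM in this assay, at which 3 of the 3 values shown sit, and on compound 2 sitting at the same limit. Compound 4 is therefore estimated at 200000 nM, between 100000 nM and 400000 nM, and is expected most likely to return only a limit again.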

Compound 4, half-maximal inhibitory concentration: > 200000 nM
Compound 4: only a limit was reported (the forecaster's own chance of this, stated with the estimate: 85%); the middle value sits exactly at the limit.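

No new step can be read from compound 2 to compound 4, cyano in place of methyl on an aromatic carbon, because both compounds give only a limit in this assay: the limit of > 200000 nM in this assay, at which 4 of the 4 values shown sit.

Going by these compounds, with no number from any of the four compounds, it stays open whether this change affects toxicity to cells at all, and how the compounds would rank.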